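This account rests on a few compounds, and the source may have more. Where it says the series, first, only, none or still open, it means among the compounds named here.

Compounds measured so far:
compound 1 `Cc1nnc(CN(C)C)n1-c1ccc(Cl)cc1C(=O)c1ccccc1` gives 0.5 mg/kg
compound 2 `Cc1nnc(CN2CCCC2)n1-c1ccc(Cl)cc1C(=O)c1ccccc1` gives 0.4 mg/kg
compound 3 `CNCc1nnc(C)n1-c1ccc(Cl)cc1C(=O)c1ccccc1` gives 0.1 mg/kg

In a functional assay on the whole organism (strain CF-1) for inhibition, with Mus musculus as the target (a lower number here means that less compound is needed, a higher number that more compound is needed for the effect), compound 3 stands lowest of the three; the step of a 4.0-fold lower number from compound 2 to compound 3 (0.60 log units; beyond the scatter) and the step of a 5.0-fold lower number from compound 1 to compound 3 (0.70 log units; beyond the scatter) are both beyond the scatter, while the step of a 1.3-fold lower number from compound 1 to compound 2 (0.10 log units; within the scatter) is within it. Compound 4 `CCNCc1nnc(C)n1-c1ccc(Cl)cc1C(=O)c1ccccc1` differs from compound 3 by methyl in place of hydrogen on a saturated chain carbon bound to an amine nitrogen. The step from compound 1 to compound 3 bears on this change, since it also altered the amine, and it was modest. Adding a methyl one bond further out is expected to give a smaller effect, in the direction of a higher number. Compound 4 is therefore expected at 0.2 mg/kg, within 0.08 mg/kg to 0.5 mg/kg, an expected step of a 2.0-fold higher number from compound 3 to compound 4 (0.30 log units; within the scatter).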

Compound 4, dose for half-maximal effect: 0.2 mg/kg
The estimate for compound 4 equals the measured number at the digits printed; the range from low to high includes it.
By their numbers in this assay, from the lowest: compounds 3, 4, 2 and 1 (each within the scatter of the next, the first and the last beyond it).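

In this assay, the step of a 2.0-fold higher number from compound 3 to compound 4 (0.30 log units; within the scatter) stays within the scatter, so methylamino and ethylamino cannot be told apart at this position. The step of a 2.0-fold lower number from compound 2 to compound 4 (0.30 log units; within the scatter) is also within the scatter, whereas a 2.5-fold lower number from compound 1 to compound 4 (0.40 log units; beyond the scatter) lies beyond it, showing that the lower number relative to dimethylamino is not confined to methylamino. Nothing measured here gives a reason for these steps. Still open, on these data alone, is whether a longer chain, such as propylamino, or a branched isopropylamino would stay in this range. As far as these compounds go, the unsubstituted primary amine also remains open.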